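The source may report more compounds than this note shows. Statements on the series, on what has been measured and on what is new or still open speak of the compounds shown alone.

In a functional assay on Bel7402/5-FU cells (Homo sapiens) for antiproliferative activity, read by MTT assay, with a stated time of 72 h (a higher number here means a weaker inhibitor, a lower number a stronger inhibitor), compound 1 `C=C1C(=O)O[C@H]2[C@H]1CC/C(Cn1cc(Cn3cc(F)c(=O)n(Cc4ccc(F)cc4)c3=O)nn1)=C\CC[C@@]1(C)O[C@@H]21` gives 4860 nM and compound 2 `C=C1C(=O)O[C@H]2[C@H]1CC/C(COC(=O)Cn1cc(F)c(=O)n(Cc3ccc(Br)cc3)c1=O)=C\CC[C@@]1(C)O[C@@H]21` gives 3240 nM, two values within the usual scatter of each other. Compound 3 `C=C1C(=O)O[C@H]2[C@H]1CC/C(COC(=O)Cn1cc(F)c(=O)n(Cc3c(F)cccc3F)c1=O)=C\CC[C@@]1(C)O[C@@H]21` differs from compound 2 in one place: 2,6-difluorophenyl in place of 4-bromophenyl on a saturated chain carbon bound to an aromatic nitrogen, with 2,6-difluorophenyl in place of 4-bromophenyl on a saturated chain carbon bound to an aromatic nitrogen. Going by the values given here, no measured pair shows this change, so no step beyond the scatter is expected in this assay, in either direction. The estimated step is small, a 1.2-fold higher number from compound 2 to compound 3 (0.07 log units; within the scatter). For compound 3 the expected value is 3800 nM, with an estimated range from 1500 nM to 9500 nM.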

Compound 3, half-maximal inhibitory concentration: 4980 nM
Compound 3: the middle estimate sits 1.3-fold (0.12 log units) below what was measured; the measured number falls inside the stated range.
By their numbers in this assay, from the lowest: compounds 2, 1 and 3 (each within the scatter of the next).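

In this assay the swap of 4-bromobenzyl for 2,6-difluorobenzyl gives a 1.5-fold higher number from compound 2 to compound 3 (0.19 log units; within the scatter) on a saturated chain carbon bound to an aromatic nitrogen. Going by these compounds alone, this is the first direct reading at this position, since compound 1 and compound 2 differ in more than one place. Here, a phenyl ring with two fluorines and one with a single bromine cannot be told apart, and no measurement offered explains this. Still open, going by these compounds, is how this position responds to a benzyl ring carrying an amine or a carboxylic acid, or to a longer chain between the ring and the aromatic nitrogen.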